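The compounds below may be only part of what the source reports. "The series", "measured", "known", "first", "only" and "open" are said of these compounds alone.

Compound 2, whose structure is `Oc1ccccc1NC(=S)Nc1ccc2[nH]ccc2c1`, stands as the only one of the three measured compounds with a definite number in an ADME assay on cells for inhibition of Amine oxidase [flavin-containing] A (Homo sapiens), read by spectrophotometry (on this read-out lower numbers stand for stronger inhibition and higher numbers for weaker inhibition), where compound 2 gives 39000 nM. Its parent compound 1, with the structure `S=C(Nc1ccccc1)Nc1ccc2[nH]ccc2c1`, gives in this assay only a limit: compound 1 shows > 30000 nM. The step from the parent is therefore a step that the limit leaves unreadable from compound 1 to compound 2, as the limit of > 30000 nM in this assay, at which 1 of the 3 values shown sits, shows. Compound 3, with the structure `S=C(Nc1ccc(Oc2ccccc2)cc1)Nc1ccc2[nH]ccc2c1`, is reported in this assay as "not active" (no number reported), without a number.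

Compound 4, with the structure `Oc1cc(Cl)ccc1NC(=S)Nc1ccc2[nH]ccc2c1`, differs from compound 2 by chloro in place of hydrogen on an aromatic carbon. Going by the values given here, no measured step involves a chloro group, and the one step that starts from compound 1 is unreadable, so no measured step bears directly on this change. The step from compound 2 to compound 4 in this assay is therefore expected to stay within the scatter, as a 1.3-fold lower number from compound 2 to compound 4 (0.11 log units; within the scatter). Compound 4 is estimated to give 30000 nM in this assay, between 10000 nM and 100000 nM.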

Compound 4, half-maximal inhibitory concentration: 39000 nM
Beside the measured number, compound 4's estimate is 1.3-fold (0.11 log units) below it, and the stated range covers the measured number.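

A chloro group, meta to a hydroxy group and para to a large group, gives in this assay no change at the digits printed from compound 2 to compound 4 (within the scatter). This is the only readable step among the compounds shown, and it shows that this ring position accepts a chlorine atom without a change in the number beyond the scatter. The step that adds the hydroxy group still cannot be read, because compound 1 has only a limit: the limit of > 30000 nM in this assay, at which 1 of the 4 values shown sits.

The compounds shown leave open whether a different group at this position, such as a methoxy group, an amine or a carboxylic acid, would move the number beyond the scatter. They also leave open whether chloro on another carbon of this ring would behave as it does here.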